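Swapping the Amide Group on Compound 3

The source may report more compounds than this note shows. Statements on the series, on what has been measured and on what is new or still open speak of the compounds shown alone.

In an ADME assay on LLC-MK2 cells (Macaca mulatta) for cytotoxicity, read by spectrophotometry and crystal violet staining, with a stated time of 4 days (on this read-out lower numbers stand for higher toxicity in this test and higher numbers for lower toxicity in this test), compound 1 (`CC(C)n1ncc2c(C(=O)Nc3ccc(F)cc3)cc(-c3cccs3)nc21`) gives > 200000 nM, which is a limit of the assay and not a number. Compound 2 (`CC(C)n1ncc2c(NC(=O)c3ccc(F)cc3)cc(-c3cccs3)nc21`) gives 50000 nM, and compound 3 (`CC(C)n1ncc2c(C(=O)N3CCc4cccnc43)cc(-c3cccs3)nc21`) gives 50000 nM, so compound 3 sits level with compound 2. Compound 4 (`CC(C)n1ncc2c(C(=O)Nc3cc(F)ccc3F)cc(-c3cccs3)nc21`) differs from compound 3 on a carbonyl carbon: a group of 9 heavy atoms (6 carbon, 1 nitrogen, 2 fluorine; one six-membered aromatic ring of carbon only) in place of a group of 9 heavy atoms (7 carbon, 2 nitrogen; one five-membered non-aromatic ring with 1 hetero atom, one six-membered aromatic ring with 1 hetero atom), on a carbonyl carbon. Among the measured compounds shown here, the one measured step bearing on this is an at least 4.0-fold lower number from compound 1 to compound 3 (0.60 log units; beyond the scatter). The entering (2,5-difluorophenyl)amino group holds a six-membered aromatic ring of carbon only, as did the group that left in that step, so a step of similar size in the opposite direction is expected. In this assay, the estimated step is a 2.4-fold higher number from compound 3 to compound 4 (0.38 log units; beyond the scatter). Compound 4 is expected at 120000 nM, within an estimated range of 50000 nM to 200000 nM.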

Compound 4, half-maximal cytotoxic concentration: 100000 nM
The estimate for compound 4 lay 1.2-fold (0.08 log units) above the measured number, within the range that was stated.
By their numbers in this assay, from the lowest: compounds 2, 3 and 4 (each within the scatter of the next). At a limit, above all of these: compound 1.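

In this assay, placing (2,5-difluorophenyl)amino on the carbonyl carbon in place of the group in compound 3 gives a 2.0-fold higher number from compound 3 to compound 4 (0.30 log units; within the scatter), so this swap shows no clear effect on the read-out. Using 2,5-difluorophenyl in place of 4-fluorophenyl on the amide-type nitrogen gives an at least 2.0-fold lower number from compound 1 to compound 4 (0.30 log units; that floor lies within the scatter), which does not separate the two groups. The size of that step cannot be fixed, because the reading for compound 1 is a limit and not a number: the limit of > 200000 nM in this assay, at which 1 of the 4 values shown sits.

As far as these compounds go, whether an amine such as piperidine on the carbonyl carbon would move the number beyond the scatter stays open.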